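A Conjugated Acid Replaces the Thioether Side Chain

A few compounds are considered here, and "the series" means these few. Any claim that something is new, unique, unknown or untested is made for them only; others in the source may bear on it.

For the measured compounds named here, compound 1 `O=C(O)/C(CSCCO)=N/OC(c1ccc(OCc2ccc3ccccc3n2)cc1)C1CCCCC1` gives 181 nM in a functional assay for inhibition of Polyunsaturated fatty acid 5-lipoxygenase (Homo sapiens) (a lower number here means a stronger inhibitor, a higher number a weaker inhibitor), the highest of the two numbers measured so far; compound 2 `O=C(O)/C(CCc1ccccc1)=N/OC(c1ccc(OCc2ccc3ccccc3n2)cc1)C1CCCCC1` gives 20 nM. Going by the values given here, the single measured step, a 9.1-fold lower number from compound 1 to compound 2 (0.96 log units; beyond the scatter), changes the same side of the shared core that compound 3 alters. Compound 3 `CC(/C=C/C(=O)O)=N\OC(c1ccc(OCc2ccc3ccccc3n2)cc1)C1CCCCC1` differs from compound 1 by a group of 8 heavy atoms (5 carbon, 1 nitrogen, 2 oxygen; no ring) in place of a group of 10 heavy atoms (5 carbon, 1 nitrogen, 3 oxygen, 1 sulfur; no ring), on an oxygen on a saturated carbon. Among the compounds with values here, no measured step covers this exchange, and the two groups share little, so the direction is open; a step beyond the scatter either way is possible. Compound 3 is expected to give 300 nM, between 60 nM and 1500 nM. That expectation amounts to a 1.7-fold higher number from compound 1 to compound 3 (0.22 log units; within the scatter).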

Compound 3, half-maximal inhibitory concentration: 40 nM
The estimate for compound 3 lay 7.5-fold (0.88 log units) above the measured number, outside the stated range (below it).
By their numbers in this assay, from the lowest: compounds 2 and 3 (each within the scatter of the next); then compound 1.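

The exchange on an oxygen on a saturated carbon gives a 4.5-fold lower number from compound 1 to compound 3 (0.66 log units; beyond the scatter) in this assay and shows that a group with no ring and no sulfur can also bring the number down from that of compound 1. A ring is therefore not required for a step beyond the scatter at this position. Nothing available here explains the step. The compounds shown do not separate the loss of sulfur and the hydroxyl from the gain of a double bond. They also leave open whether an amide or a longer chain would serve in place of the carboxylic acid group of compound 3.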